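Methoxy in place of methyl: working notes

This account rests on a few compounds, and the source may have more. Where it says the series, first, only, none or still open, it means among the compounds named here.

In a functional assay on HUVEC cells (Homo sapiens) for antiproliferative activity (on this read-out lower numbers stand for stronger inhibition of growth and higher numbers for weaker inhibition of growth), compound 1 `COc1cc(/C=C/C(=O)Nc2ccc(NC(=O)[C@@H](O)[C@H](N)CC3CCCCC3)cc2C)cc(OC)c1OC` gives 1800 nM as the higher of the two single numbers. Compound 2 `COc1cc(NC(=O)/C=C/c2cc(OC)c(OC)c(OC)c2)ccc1NC(=O)[C@@H](O)[C@H](N)CCc1ccccc1` gives 700 nM as the lower one, a gap beyond the scatter. Compound 3 `COc1cc(/C=C/C(=O)Nc2ccc(NC(=O)[C@@H](O)[C@H](N)CC3CCCCC3)cc2)cc(OC)c1OC` has no single number and gives 670 nM; 2000 nM (2 entries) as separate entries. Compound 4 `COc1cc(NC(=O)[C@@H](O)[C@H](N)CC2CCCCC2)ccc1NC(=O)/C=C/c1cc(OC)c(OC)c(OC)c1` differs from compound 1 by methoxy in place of methyl on an aromatic carbon and is not yet measured. In this assay a slight move to a lower number is expected, with no step beyond the scatter. This rests on compound 2, which also carries methoxy and gives 700 nM here, and on the spread in the several entries of compound 3 in this assay, 670 nM; 2000 nM (2 entries) alone. The estimated step of a 1.8-fold lower number from compound 1 to compound 4 (0.26 log units; within the scatter) is expected to stay within the scatter. Compound 4 is estimated at 1000 nM with an expected range of 400 nM to 2500 nM for now.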

Compound 4, concentration for 50% growth inhibition: 1200 nM
Estimate against measurement, compound 4: 1.2-fold (0.08 log units) below; the range from low to high includes it.
By their numbers in this assay, from the lowest: compounds 2, 4 and 1 (each within the scatter of the next, the first and the last beyond it).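

In this assay, among these compounds, on an aromatic carbon ortho to a large group and meta to a large group, methoxy in place of methyl gives the first matched step at this position: a 1.5-fold lower number from compound 1 to compound 4 (0.18 log units; within the scatter). The change adds one hydrogen-bond acceptor by count, yet the read-out does not separate the two compounds. Repeat entries of a single compound spread wider than this step: the several entries of compound 3 in this assay, 670 nM; 2000 nM (2 entries)

On these data alone, whether ethoxy, chlorine or an amine on this carbon would move the number beyond the scatter stays open. So does whether the change behaves alike with the side chain of compound 2.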